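This account rests on a few compounds, and the source may have more. Where it says the series, first, only, none or still open, it means among the compounds named here.

Measured so far in a functional assay on MCF7 cells (Homo sapiens) for antiproliferative activity, read by MTT assay, with a stated time of 48 h; on this read-out higher numbers stand for weaker inhibition and lower numbers for stronger inhibition
- compound 1 `Cc1ccc(-c2nnc(NC(=O)/C=C/c3ccc(C(F)(F)F)cc3)s2)cc1` gives 1.1 ug/mL
- compound 2 `Cc1ccc(/C=C/C(=O)Nc2nnc(-c3ccc(Cl)cc3)s2)cc1` gives 1.44 ug/mL
- compound 3 `COc1ccc(-c2nnc(NC(=O)/C=C/c3ccc(C)cc3)s2)cc1` gives 0.31 ug/mL

Compound 3 has the lowest number of the three, and the values of compound 1 and compound 2 both lie beyond the scatter from it. The next compound is compound 4 `COc1ccc(-c2nnc(NC(=O)/C=C/c3ccc(F)cc3)s2)cc1`, which differs from compound 3 by fluoro in place of methyl on an aromatic carbon in a change from 4-methylphenyl to 4-fluorophenyl, fluoro in place of methyl on an aromatic carbon.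

Going by the values given here, the only measured single-place step is a 4.6-fold lower number from compound 2 to compound 3 (0.67 log units; beyond the scatter) and it is methoxy in place of chloro, so it does not cover this place. Among the compounds with values here, it shows only that one exchange on an aromatic carbon can move the number beyond the scatter in this small set. Compound 1 differs from compound 3 in more than one place and offers no clean comparison. Within the data shown here, with compound 3 at 0.31 ug/mL as the lowest value so far, a small rise is expected rather than a further drop. The expected step is a 1.6-fold higher number from compound 3 to compound 4 (0.21 log units; within the scatter) in this assay and remains a working estimate. For compound 4 the estimated value is 0.5 ug/mL with an expected range of 0.17 ug/mL to 1.5 ug/mL at this stage.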

Compound 4, half-maximal inhibitory concentration: 0.85 ug/mL
Estimate against measurement, compound 4: 1.7-fold (0.23 log units) below; the range from low to high includes it.
By their numbers in this assay, from the lowest: compound 3; then compounds 4, 1 and 2 (each within the scatter of the next).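

With methoxy held constant on the other aromatic ring, fluoro in place of methyl on an aromatic carbon, para to a large group, gives a 2.7-fold higher number from compound 3 to compound 4 (0.44 log units; beyond the scatter) in this assay. Going by these compounds alone, this is the first single-place step at the position where 4-methylphenyl changes to 4-fluorophenyl, and it shows that the read-out responds to a one-atom exchange there, with the methyl-bearing compound 3 giving the lower number of the pair. No measured evidence bears on the origin of this step.

Going by these compounds, whether the same step would appear with chloro in place of methoxy on the other ring remains open. Also open, on these data alone, is how an amine, a hydroxyl group or a longer alkyl chain at this position would read.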